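This account rests on a few compounds, and the source may have more. Where it says the series, first, only, none or still open, it means among the compounds named here.

Compound 1 `COc1ccc(/C=C\c2cc(OC)c(OC)c(OC)c2)cc1OCc1ccc(C=O)cc1`, which carries a formyl group on an aromatic carbon, gives 46000 nM in an ADME assay on HEK293 cells (Homo sapiens) for cytotoxicity, read by CCK-8 assay, with a stated time of 48 h; a lower number here means a stronger inhibitor, a higher number a weaker inhibitor. Compound 2 `COc1ccc(/C=C\c2cc(OC)c(OC)c(OC)c2)cc1OCc1ccc(CN2CCCC[C@@H]2C(=O)O)cc1`, with (2-carboxypiperidin-1-yl)methyl in that place, gives 42000 nM in this assay. Compound 3 `COc1ccc(/C=C\c2cc(OC)c(OC)c(OC)c2)cc1OCc1ccc(CN2CCCCC2C(=O)O)cc1` is reported only as a limit, > 50000 nM. What separates the last two structures is the fact that one of compounds 2 and 3 is drawn with a defined configuration and the other without, at the place where they differ. On the numbers shown, compound 3 stands at the limit of > 50000 nM in this assay, at which 1 of the 3 values shown sits, and it does not stand apart from the other two: the measured steps are a 1.1-fold lower number from compound 1 to compound 2 (0.04 log units; within the scatter), an at least 1.0-fold higher number from compound 1 to compound 3 (0.03 log units; that floor lies within the scatter) and an at least 1.1-fold higher number from compound 2 to compound 3 (0.07 log units; that floor lies within the scatter).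

The next structure is compound 4 `COc1ccc(/C=C\c2cc(OC)c(OC)c(OC)c2)cc1OCc1ccc(CNCCN(C)C)cc1`, and the change to it is (2-(dimethylamino)ethyl)amino in place of 2-carboxypiperidin-1-yl on a saturated chain carbon bound to an aromatic carbon. The same difference, cut one bond further out, reads (2-carboxypiperidin-1-yl)methyl to ((2-(dimethylamino)ethyl)amino)methyl. Going by the values given here, the steps that bear on it are those made at this same place, and a small step is expected since compound 2 moved by only a 1.1-fold lower number from compound 1 to compound 2 (0.04 log units; within the scatter). None of them tests the entering group, however, so the expectation stays loose and leans only slightly towards a lower number. The expected change is an at least 1.4-fold lower number from compound 3 to compound 4 (0.15 log units; that floor lies within the scatter), which is an estimate. For compound 4 the estimated value is 35000 nM, with an expected range from 15000 nM to 60000 nM.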

Compound 4, half-maximal inhibitory concentration: 39000 nM
Beside the measured number, compound 4's estimate is 1.1-fold (0.05 log units) below it, and the stated range covers the measured number.
By their numbers in this assay, from the lowest: compounds 4, 2 and 1 (each within the scatter of the next). At a limit, above all of these: compound 3.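

In this assay, going by these compounds alone, the group at this place was changed for the first time from one with a ring and a carboxylic acid to the open-chain (2-(dimethylamino)ethyl)amino, and the step is a 1.1-fold lower number from compound 2 to compound 4 (0.03 log units; within the scatter), while the comparison with the formyl compound reads a 1.2-fold lower number from compound 1 to compound 4 (0.07 log units; within the scatter). So compounds 2 and 4 stand within the scatter of each other on a saturated chain carbon bound to an aromatic carbon, whether the group there carries a ring and a carboxylic acid or neither. Compound 3 is reported only as a limit, so its step gives no more than a floor, an at least 1.2-fold lower number from compound 3 to compound 4 (0.10 log units; that floor lies within the scatter), and that floor adds nothing firm to the picture: the limit of > 50000 nM in this assay, at which 1 of the 4 values shown sits.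

What the compounds shown leave open is whether the ring or the carboxylic acid counts on its own, which a plain piperidin-1-yl or a morpholine at this place could separate. They also do not tell whether a longer chain in place of the ethyl link, or a primary amine at its end, would carry the number beyond the scatter.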